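A few compounds are considered here, and "the series" means these few. Any claim that something is new, unique, unknown or untested is made for them only; others in the source may bear on it.

Measured compounds:
Compound 1 `CCCCCCCCN(C)C(=O)Cn1cc(Cc2cnc(=O)n(CC(=O)NC)c2)c(=O)nc1SCc1ccc(F)cc1`: 42%
Compound 2 `CCCCCCCCN(C)C(=O)Cn1cc(Cc2cnc(=O)n(CC(=O)N3CCNC(=O)C3)c2)c(=O)nc1SCc1ccc(F)cc1`: 55%

In a functional assay on a cell-free system (plasma, Oryctolagus cuniculus) for inhibition of platelet-activating factor acetylhydrolase (Homo sapiens), tested at 100 nM (on this read-out higher numbers stand for more inhibition at the one concentration tested (going by the name of the read-out) and lower numbers for less inhibition), compound 2 gives the higher of the two numbers, and its nearest neighbour is compound 1, the step being a number 13 percentage points higher from compound 1 to compound 2 (beyond the scatter). Compound 3 `CCCCCCCCN(C)C(=O)Cn1cc(Cc2cnc(=O)n(CC(=O)N3CCN(C(C)=O)CC3)c2)c(=O)nc1SCc1ccc(F)cc1` differs from compound 2 by 4-acetylpiperazin-1-yl in place of 3-oxopiperazin-1-yl on a carbonyl carbon. Going by the values given here, the only measured step, a number 13 percentage points higher from compound 1 to compound 2 (beyond the scatter), changed the group on the same carbonyl carbon and was modest, so a change within the scatter, or a small one in either direction, is expected here. Compound 3 is therefore estimated at 50% (range 30% to 70%), a step of a number 5 percentage points lower from compound 2 to compound 3 (within the scatter).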

Compound 3, a percentage reported as inhibition, at one concentration (the size of the read-out at that concentration, not a potency): 49%
For compound 3 the middle estimate is 1 percentage points above the measured one; measured number inside the range.
By their numbers in this assay, from the lowest: compounds 1, 3 and 2 (each within the scatter of the next, the first and the last beyond it).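

In this assay, the change to 4-acetylpiperazin-1-yl gives a number 6 percentage points lower from compound 2 to compound 3 (within the scatter) even though the entering group has more heavy atoms and no hydrogen-bond donor, so neither difference has a measurable effect on this comparison. Compound 3 also cannot be separated from the methylamino compound, with a number 7 percentage points higher from compound 1 to compound 3 (within the scatter), so it does not show whether the ring itself matters here. No available evidence explains these results.

On these data alone, it remains open how a free amine or a carboxylic acid on this part of the side chain would read out. Results at a single concentration also leave the relative potencies of these compounds open.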